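Cyclobutylsulfanyl in Place of a Fluoroalkoxy Group on the Carbonyl

This account rests on a few compounds, and the source may have more. Where it says the series, first, only, none or still open, it means among the compounds named here.

Three compounds have been measured in a functional assay on isolated protein for inhibition of Glucose-dependent insulinotropic receptor (Homo sapiens), read by HTRF and cAMP accumulation; on this read-out higher numbers stand for an effect only at larger amounts of compound and lower numbers for an effect already at smaller amounts:
compound 1, `Cc1nc(S(C)(=O)=O)ccc1Oc1ncnc(OC2CCN(C(=O)OC(C)(C)C#N)CC2)c1F`, gives 92.9 nM;
compound 2, `Cc1nc(S(C)(=O)=O)ccc1Oc1ncnc(OC2CCN(C(=O)OC(C)(C)CF)CC2)c1F`, gives 19.9 nM;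
compound 3, `Cc1nc(S(C)(=O)=O)ccc1Oc1ncnc(OC2CCN(C(=O)OC(C)F)CC2)c1F`, gives 65.5 nM.

Compound 3 stands second highest of the three numbers; compound 1 sits within the scatter of it, whereas the step of a 3.3-fold higher number from compound 2 to compound 3 (0.52 log units; beyond the scatter) lies beyond it. Compound 4, `Cc1nc(S(C)(=O)=O)ccc1Oc1ncnc(OC2CCN(C(=O)SC3CCC3)CC2)c1F`, differs from compound 3 in one place: a group of 5 heavy atoms (4 carbon, 1 sulfur; one four-membered non-aromatic ring of carbon only) in place of a group of 4 heavy atoms (2 carbon, 1 oxygen, 1 fluorine; no ring), on a carbonyl carbon. Going by the values given here, none of the measured steps changes the atom bound to the carbonyl carbon; the steps of a 4.7-fold lower number from compound 1 to compound 2 (0.67 log units; beyond the scatter) and a 1.4-fold lower number from compound 1 to compound 3 (0.15 log units; within the scatter) only vary the group on the oxygen. A modest step toward a lower number is expected, since the larger group gave the lower number in a 3.3-fold higher number from compound 2 to compound 3 (0.52 log units; beyond the scatter), estimated as a 1.6-fold lower number from compound 3 to compound 4 (0.21 log units; within the scatter). Compound 4 is estimated at 40 nM, between 10 nM and 160 nM.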

Compound 4, half-maximal effective concentration: 8.51 nM
Beside the measured number, compound 4's estimate is 4.7-fold (0.67 log units) above it; measured number outside the range, below it.
By their numbers in this assay, from the lowest: compound 4; then compound 2; then compounds 3 and 1 (each within the scatter of the next).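

Cyclobutylsulfanyl is the first group here to change the atom bound to the carbonyl carbon, and in this assay it gives the lowest number of the four, with a 7.7-fold lower number from compound 3 to compound 4 (0.89 log units; beyond the scatter), a 2.3-fold lower number from compound 2 to compound 4 (0.37 log units; beyond the scatter) and an 11-fold lower number from compound 1 to compound 4 (1.04 log units; beyond the scatter). The earlier steps shown here varied only the group on the oxygen, so this position also accepts a sulfur-linked ring without any loss on this read-out.

Nothing available explains this gain. Also open, going by these compounds, is how much the sulfur and the ring each contribute, which a cyclobutoxy group on the same carbonyl carbon would help separate.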